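The source may hold more compounds than are shown below. What is called first, only, known or untested is meant among the compounds shown, and "the series" means these compounds.

Among the measured compounds shown here, compound 2 `Nc1nc(N)c2cc(CSC(=S)N3CCN(c4ccc(Cl)c(Cl)c4)CC3)ccc2n1` gives 6680 nM in a functional assay on HCT-116 cells (Homo sapiens) for antiproliferative activity, read by MTT assay, with a stated time of 72 h (on this read-out higher numbers stand for weaker inhibition and lower numbers for stronger inhibition), the highest of the two numbers measured so far, and compound 1 `Cc1ccc(N2CCN(C(=S)SCc3ccc4nc(N)nc(N)c4c3)CC2)cc1` stands nearest with 5510 nM. The step of a 1.2-fold higher number from compound 1 to compound 2 (0.08 log units; within the scatter) lies within the scatter, so no order between the two compounds can be read from it. Compound 3 `Nc1nc(N)c2cc(CSC(=S)N3CCN(c4ncccn4)CC3)ccc2n1` has not yet been measured. It differs from compound 2 in one place: pyrimidin-2-yl in place of 3,4-dichlorophenyl on an amine nitrogen in a ring. For the measured compounds named here, the one measured step that bears on this change is the exchange of one aromatic group for another on the same ring nitrogen, a 1.2-fold higher number from compound 1 to compound 2 (0.08 log units; within the scatter), which stayed within the scatter. Going by the values given here, on that basis, and with only this single comparison to go by, no step beyond the scatter is expected for compound 3 in this assay in either direction. Compound 3 is therefore estimated at 6000 nM, with a range from 2500 nM to 15000 nM. The expected step is a 1.1-fold lower number from compound 2 to compound 3 (0.05 log units; within the scatter).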

Compound 3, half-maximal inhibitory concentration: 5840 nM
The estimate for compound 3 lay 1.0-fold (0.01 log units) above the measured number, and the stated range covers the measured number.
By their numbers in this assay, from the lowest: compounds 1, 3 and 2 (each within the scatter of the next).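

In this assay, pyrimidin-2-yl in place of 3,4-dichlorophenyl gives a 1.1-fold lower number from compound 2 to compound 3 (0.06 log units; within the scatter) and pyrimidin-2-yl in place of 4-methylphenyl gives a 1.1-fold higher number from compound 1 to compound 3 (0.03 log units; within the scatter) on the same amine nitrogen in a ring. Compounds 1 and 2 carried only an aromatic ring of carbon at this place, whereas compound 3 brings a ring with 2 hetero atoms and 2 hydrogen-bond acceptors, and across these three compounds this change moves the number by no more than the scatter. Nothing measured here offers an explanation for how close these numbers lie.

All three compounds still carry a six-membered aromatic ring on this nitrogen. As far as these compounds go, whether a saturated group such as cyclohexyl, a benzyl group or a simple acetyl group there would shift the number stays open, as does the effect of an amine or a carboxylic acid on the aromatic ring.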